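A few compounds are considered here, and "the series" means these few. Any claim that something is new, unique, unknown or untested is made for them only; others in the source may bear on it.

Measured so far in a functional assay on PPC-1 cells (Homo sapiens) for antiproliferative activity, read by sulforhodamine B assay; on this read-out lower numbers stand for stronger inhibition and higher numbers for weaker inhibition:
compound 1 `CCCCCCCCCCCCCCCCCCNC(=O)[C@@H]1CSC(c2cccc(O)c2)N1` gives 1200 nM
compound 2 `CCCCCCCCCCCCCCCCCCNC(=O)[C@@H]1CSC(c2ccc(N(C)C)cc2)N1` gives 1100 nM
compound 3 `CCCCCCCCCCCCCCCCCCNC(=O)[C@H]1NC(c2cc(OC)c(OC)c(OC)c2)SC1(C)C` gives 18800 nM

Among these three numbers compound 3 stands highest; its gap to compound 1 and its gap to compound 2 both lie beyond the scatter. Compound 4 `CCCCCCCCCCCCCCCCCCNC(=O)[C@H]1NC(c2ccc(N(C)C)cc2)SC1(C)C` has not yet been measured. It arises from compound 3 by 4-(dimethylamino)phenyl in place of 3,4,5-trimethoxyphenyl on a saturated ring carbon. For the measured compounds named here, the only measured step that touches this exchange is a 1.1-fold lower number from compound 1 to compound 2 (0.04 log units; within the scatter), and that step swaps in the same entering group from a different leaving group, on a core without the two methyl groups. Going by the values given here, no measured pair exchanges 3,4,5-trimethoxyphenyl for 4-(dimethylamino)phenyl, and no measured pair separates the core of compound 3 from the core of compound 2. Compound 2, which carries 4-(dimethylamino)phenyl, gives 1100 nM. A lower number for compound 4 in this assay is therefore expected, though its size is uncertain. The expected step is a 3.1-fold lower number from compound 3 to compound 4 (0.50 log units; beyond the scatter). Compound 4 is estimated at 6000 nM, within 1500 nM to 20000 nM.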

Compound 4, half-maximal inhibitory concentration: > 20000 nM
Compound 4 ended at the assay's limit; the forecaster's own chance of this, stated with the estimate: 5%; middle value at least 3.3-fold (0.52 log units) away from the limit.
By their numbers in this assay, from the lowest: compounds 2 and 1 (each within the scatter of the next); then compound 3. At a limit, above all of these: compound 4.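

In this assay, compound 4 ends at a limit of the assay rather than at a number: the limit of > 20000 nM in this assay, at which 1 of the 4 values shown sits. Placing 4-(dimethylamino)phenyl where 3,4,5-trimethoxyphenyl stood gives an at least 1.0-fold higher number from compound 3 to compound 4 (0.02 log units; that floor lies within the scatter), so the exchange brought no lower number on this core, and the floor of the step does not separate the two compounds. Compound 2 gives 1100 nM with the same 4-(dimethylamino)phenyl on a core without the two methyl groups, so that group alone does not carry this number over to the core of compound 4.

On these data alone, how far compound 4 lies beyond its limit stays open, as does the effect of 3,4,5-trimethoxyphenyl on the core without the two methyl groups. Also open, as far as these compounds go, is whether a single methyl group in place of the two, or a shorter chain on the amide, would change these numbers.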